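This account rests on a few compounds, and the source may have more. Where it says the series, first, only, none or still open, it means among the compounds named here.

Measured compounds:

Compound 1, `COc1cc2c(cc1O)CCC(C)(CC(=O)O)O2`, in an ADME assay on SH-SY5Y cells (Homo sapiens) for cytotoxicity, read by MTT assay, with a stated time of 24 h, tested at 50 uM (on this read-out lower numbers stand for a stronger effect and higher numbers for a weaker effect at the one concentration tested), compound 1 gives 61%.
Compound 2, `COc1cc2c(cc1O)CCC(C)(CC(=O)N[C@@H](C)C(=O)O)O2`, in this assay compound 2 gives 100%.

Compound 2 stands highest of the two numbers; its nearest neighbour is compound 1, with the step of a number 39 percentage points higher from compound 1 to compound 2 (beyond the scatter) separating them. Compound 3, `COc1cc2c(cc1O)CCC(C)(CC(=O)N[C@H](C(=O)O)C(C)C)O2`, has not yet been measured in this assay. It differs from compound 2 by isopropyl in place of methyl on a saturated chain carbon bound to an amide-type nitrogen and a carbonyl carbon.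

Among the compounds with values here, the only measured step, a number 39 percentage points higher from compound 1 to compound 2 (beyond the scatter), concerns a different change, the amide replacing the carboxylic acid, and so does not bear on the exchange of methyl for isopropyl on the chain carbon. Within the data shown here, no measured pair shows the effect of that exchange. With nothing to point in either direction, the expected step of a number 2 percentage points lower from compound 2 to compound 3 (within the scatter) is none beyond the scatter. Compound 3 is therefore estimated at 98% in this assay, within a range from 82% to 112%.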

Compound 3, a percentage reported as activity, at one concentration (the size of the read-out at that concentration, not a potency): 79.3%
Beside the measured number, compound 3's estimate is 18.7 percentage points above it, and the stated range ends above it.
By their numbers in this assay, from the lowest: compound 1; then compound 3; then compound 2.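

Within the data shown here, the exchange of methyl for isopropyl on a saturated chain carbon bound to an amide-type nitrogen and a carbonyl carbon is the first change at this position that can be read in this assay, and it brings a number 20.7 percentage points lower from compound 2 to compound 3 (beyond the scatter) as a step beyond the scatter. Placing (1-carboxy-2-methylpropyl)amino in place of hydroxy on a carbonyl carbon still gives a number 18.3 percentage points higher from compound 1 to compound 3 (beyond the scatter), so the number depends on the group carried at this chain carbon and not on the amide-type link alone. No evidence is at hand that accounts for this difference.

The compounds shown leave open how the number would move with a longer chain, a phenyl ring, an amine or a second carboxylic acid on this chain carbon. They also leave open whether a hydrogen there, as in a plain glycine amide, would follow the same course, and whether the step from methyl to isopropyl would hold on a changed core.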